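This account rests on a few compounds, and the source may have more. Where it says the series, first, only, none or still open, it means among the compounds named here.

Measured so far in a functional assay on NCI-H446 cells (Homo sapiens) for cytotoxicity, read by luminescence and CellTiter-Glo, with a stated time of 24 h; a lower number here means a stronger inhibitor, a higher number a weaker inhibitor:
compound 1 `C=C1C[C@]23C[C@@]1(O)CC[C@H]2[C@@]12C=C[C@H](O)[C@@](C)(C(=O)O1)[C@H]2[C@@H]3C(=O)OC` — a limit only, > 10000 nM
compound 2 `COC(=O)/C=C/Oc1ccc2c(c1C)[C@H](C(=O)OC)[C@@]13CC(=O)[C@@](C)(CC[C@@H]21)C3` — a limit only, > 10000 nM
compound 3 `C=C1C[C@]23C[C@@]1(O)CC[C@H]2c1cc2c(C(=O)OC)coc2c(C)c1[C@@H]3C(=O)OC` — a limit only, > 10000 nM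

Compound 1 stands at the assay limit; every value shown sits there as well, in the limit of > 10000 nM in this assay, at which 3 of the 3 values shown sit, and the numbers do not separate compound 1 from compound 2 or compound 3. Compound 4 `C=C1[C@@H](O)[C@]23C[C@@]1(O)CC[C@H]2[C@@]12C=C[C@H](O)[C@@](C)(C(=O)O1)[C@H]2[C@@H]3C(=O)OC` differs from compound 1 by hydroxy in place of hydrogen on a saturated ring carbon. Within the data shown here, no step between two measured compounds is available; the only guide is that all three measured values are limits. The expected step is a step that the limit leaves unreadable from compound 1 to compound 4, none beyond the scatter. Compound 4 is estimated at 15000 nM, within 4000 nM to 60000 nM, and is expected most likely to come back as a limit again.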

Compound 4, half-maximal inhibitory concentration: > 10000 nM
Compound 4: no number, only a limit (the forecaster's own chance of this, stated with the estimate: 85%); the middle value does not contradict the limit.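

Compound 1 and compound 4 both give only a limit, so no step can be read between them: the limit of > 10000 nM in this assay, at which 4 of the 4 values shown sit.
In this assay the compounds shown leave open which structural change would give a number rather than a limit.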